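A few compounds are considered here, and "the series" means these few. Any claim that something is new, unique, unknown or untested is made for them only; others in the source may bear on it.

Compound 1 `CC1CCCCC1Oc1cccc2ccc(N)nc12` gives 32 nM in an assay on cells with melanin-concentrating hormone receptor 1 (Homo sapiens) as the target, read by radioligand binding; on this read-out lower numbers stand for stronger inhibition and higher numbers for weaker inhibition.
Compound 2 `Nc1ccc2cccc(OCC3CCCO3)c2n1` returns only a limit, > 2000 nM, in this assay.
Compound 3 `CC(CC(C)(C)C)Oc1cccc2ccc(N3CCCC3)nc12` also returns only a limit, > 2000 nM, in this assay.

Compound 2 therefore stands at the limit of > 2000 nM in this assay, at which 2 of the 3 values shown sit, so it has no number of its own and cannot be ordered against compound 3, while compound 1 is clearly the stronger of the pair compared with compound 2. Compound 4 `CCCCCOc1cccc2ccc(N)nc12` has not yet been measured in this assay. It differs from compound 2 by butyl in place of oxolan-2-yl on a saturated chain carbon bound to an oxygen on an aromatic ring. Among the compounds with values here, no measured step of this kind exists here, so the expectation leans on compound 1, whose all-carbon ether substituent gave 32 nM. A gain of about an at least 6.6-fold lower number from compound 2 to compound 4 (0.82 log units; beyond the scatter) is expected, with real uncertainty. Compound 4 is estimated at 300 nM, between 60 nM and 2000 nM.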

Compound 4, half-maximal inhibitory concentration: 580 nM
Compound 4: the middle estimate sits 1.9-fold (0.29 log units) below what was measured; the range from low to high includes it.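

Putting butyl in place of oxolan-2-yl, on a saturated chain carbon bound to an oxygen on an aromatic ring, gives in this assay an at least 3.4-fold lower number from compound 2 to compound 4 (0.53 log units; beyond the scatter). Within the data shown here, this is the first measured step at this place, and it shows that the open all-carbon chain reaches a numerical value where the ring-bearing group reached none. Compound 2 has only a limit, so the step gives a minimum size and not an exact one: the limit of > 2000 nM in this assay, at which 2 of the 4 values shown sit.

As far as these compounds go, it remains open whether the ring itself or its oxygen accounts for the step. From the compounds shown here alone, how a cyclopentylmethyl group or a longer chain would read at this place also remains open.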